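This account rests on a few compounds, and the source may have more. Where it says the series, first, only, none or still open, it means among the compounds named here.

Values measured so far in a functional assay on MDA-MB-231 cells (Homo sapiens) for antiproliferative activity, with a stated time of 4 days; on this read-out higher numbers stand for weaker inhibition and lower numbers for stronger inhibition

Compound 1 `COc1ccc(-c2[nH]c3ccc(OC)cc3c2C=C(C#N)C#N)cc1` gives 590 nM
Compound 2 `CCCCc1ccc2[nH]c(-c3ccc(OC)cc3)c(C=C(C#N)C#N)c2c1` gives 26 nM
Compound 3 `CCCCCCc1ccc2[nH]c(-c3ccc(OC)cc3)c(C=C(C#N)C#N)c2c1` gives 46 nM

Compound 2 sits at the low end of these numbers, together with compound 3, since a 1.8-fold higher number from compound 2 to compound 3 (0.25 log units; within the scatter) stays within the scatter. Compound 1 stands well above both.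

Compound 4 `CCCCc1ccc2[nH]c(-c3ccc(CC)cc3)c(C=C(C#N)C#N)c2c1` comes from compound 2 through one change ethyl in place of methoxy on an aromatic carbon in which ethyl replaces methoxy on an aromatic carbon, para to a large group. The closest measured swaps also put a carbon chain in place of a methoxy, but a different methoxy on the core. Both were large: a 23-fold lower number from compound 1 to compound 2 (1.36 log units; beyond the scatter) and a 13-fold lower number from compound 1 to compound 3 (1.11 log units; beyond the scatter) in the downward direction. Within the data shown here, no measured pair changes the 4-methoxyphenyl group itself, so those steps are only a loose guide here, and a further large fall from compound 2 is not assumed. The expected result is a 1.8-fold higher number from compound 2 to compound 4 (0.27 log units; within the scatter) and it is not expected to lie clearly beyond the scatter. Compound 4 is estimated at 48 nM with an expected range from 12 nM to 200 nM in this assay testing.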

Compound 4, half-maximal inhibitory concentration: 76 nM
Compound 4: the middle estimate sits 1.6-fold (0.20 log units) below what was measured; the measured number falls inside the stated range.
By their numbers in this assay, from the lowest: compounds 2, 3 and 4 (each within the scatter of the next, the first and the last beyond it); then compound 1.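

In this assay, putting ethyl in place of methoxy on the 4-methoxyphenyl group gives a 2.9-fold higher number from compound 2 to compound 4 (0.47 log units; beyond the scatter) and so shows that this position responds to the swap, though only modestly. The earlier swap of a carbon chain for the methoxy on the core gave a 23-fold lower number from compound 1 to compound 2 (1.36 log units; beyond the scatter) and a 13-fold lower number from compound 1 to compound 3 (1.11 log units; beyond the scatter) in the opposite direction, so the same kind of change does not act alike at the two places. The swap also removes an oxygen and its one hydrogen-bond acceptor, but no measurement available here explains the rise.

As far as these compounds go, what a hydroxyl or an amine would do in place of the methoxy remains open. So does whether a longer chain such as propyl at this position would continue the rise seen with ethyl or reverse it.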